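mGlu2 positive allosteric modulators: aryloxy exchange at the ether

A few compounds are considered here, and "the series" means these few. Any claim that something is new, unique, unknown or untested is made for them only; others in the source may bear on it.

Measured so far:
- compound 1 `CC(C)CCn1ccc(-c2ccc(OCC3CC3)cc2)c(C#N)c1=O`: 290 nM
- compound 2 `CC(C)CCn1ccc(-c2ccc(OC3CCOCC3)c(Cl)c2)c(C#N)c1=O`: 186 nM
- compound 3 `Cc1cc(Oc2ccc(-c3ccn(CC4CC4)c(=O)c3C#N)cc2)ccn1`: 832 nM

In a functional assay on CHO cells for positive allosteric modulation of metabotropic glutamate receptor 2 (Homo sapiens), read by scintillation counting and GTPgammaS binding, with a stated time of 30 min (on this read-out lower numbers stand for an effect already at smaller amounts and higher numbers for an effect only at larger amounts of compound), compound 1 gives 290 nM and sits second highest of the three numbers. Its nearest neighbour is compound 2, whose value 186 nM lies within the scatter of compound 1, so no order between the two is claimed. Compound 3 gives 832 nM, a gap to compound 1 that is beyond the scatter; compound 3 differs from compound 1 in more than one place, so this gap cannot be tied to a single change.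

Compound 4 `Cc1ccc(Oc2ccc(-c3ccn(CCC(C)C)c(=O)c3C#N)cc2)c(C)n1` is not yet measured. It differs from compound 1 in one place: 2,6-dimethylpyridin-3-yl in place of cyclopropylmethyl on an oxygen on an aromatic ring. Among the compounds with values here, compound 3 is the only measured compound that carries a ring on that oxygen, and it carries the highest number of the set, but its second difference from compound 1 leaves the size of a pure ether exchange open.

For compound 4 a modest move toward a higher number in this assay is expected, a 1.6-fold higher number from compound 1 to compound 4 (0.19 log units; within the scatter), with a real chance that the step stays within the scatter. The estimate for compound 4 is 450 nM, with a range from 150 nM to 1400 nM.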

Compound 4, half-maximal effective concentration: 100 nM
Beside the measured number, compound 4's estimate is 4.5-fold (0.65 log units) above it; the whole stated range lies above it.
By their numbers in this assay, from the lowest: compounds 4, 2 and 1 (each within the scatter of the next, the first and the last beyond it); then compound 3.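

In this assay, within the data shown here, the exchange of cyclopropylmethyl for 2,6-dimethylpyridin-3-yl on an oxygen on an aromatic ring gives a 2.9-fold lower number from compound 1 to compound 4 (0.46 log units; beyond the scatter), the only step in this set between compounds that differ in one place. Compound 4 shows that this oxygen can carry an aromatic ring with a ring nitrogen and two methyl groups in place of the smaller cyclopropylmethyl without a move to a higher number, so a ring on that oxygen does not by itself bring a number like that of compound 3 at 832 nM, and compound 3 differs from compound 1 in more than one place. No measurement at hand gives a reason for this step.

The step cannot yet be divided among the parts of the entering group: a plain phenyl, a pyridin-3-yl without the two methyl groups, or a 2-methylpyridin-3-yl on the same oxygen would each separate the contribution of the ring nitrogen from that of the methyl groups. On these data alone, it also remains open how far the step extends to other groups on that oxygen, such as a morpholinoethyl chain or a benzyl group.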